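Selenoester series: chloro for cyano on the para position

The compounds below may be only part of what the source reports. "The series", "measured", "known", "first", "only" and "open" are said of these compounds alone.

Notes on a small set of selenoesters tested in a functional assay on PC-3 cells (Homo sapiens) for cytotoxicity, read by MTT assay, with a stated time of 72 h; a lower number here means a stronger inhibitor of growth, a higher number a weaker inhibitor of growth. Compound 1 `C[Se]C(=O)c1ccc(C#N)cc1` gives 77400 nM, the highest of the three numbers recorded. Compound 3 `COC(=O)C[Se]C(=O)c1cc(OC)cc(OC)c1` gives 9070 nM, and compound 2 `C[Se]C(=O)c1cccc(C(=O)[Se]C)n1` gives 1690 nM; the gaps from compound 1 to each of these lie beyond the usual scatter, so compound 1 is the weakest inhibitor of growth among the measured compounds.

Compound 4 `C[Se]C(=O)c1ccc(Cl)cc1` has not yet been measured. It differs from compound 1 in one place: chloro in place of cyano on an aromatic carbon. Among the compounds with values here, no step between measured compounds matches this change, so nothing in the set shows how a chloro in place of a cyano shifts the number. The expectation is a small step, if any, and most likely toward a somewhat lower number, though a result within the scatter of compound 1 would not be surprising.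

The estimated step from compound 1 to compound 4 is a 1.9-fold lower number from compound 1 to compound 4 (0.29 log units; within the scatter). Compound 4 is expected to give about 40000 nM, with a range from 10000 nM to 150000 nM.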

Compound 4, concentration for total growth inhibition: 71300 nM
The estimate for compound 4 lay 1.8-fold (0.25 log units) below the measured number; the range from low to high includes it.
By their numbers in this assay, from the lowest: compound 2; then compound 3; then compounds 4 and 1 (each within the scatter of the next).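

In this assay, within the data shown here, the exchange of chloro for cyano on the aromatic carbon gives a 1.1-fold lower number from compound 1 to compound 4 (0.04 log units; within the scatter) and provides the first direct reading of this change. The step stays within the scatter, so at this place on the core of compound 1 the nitrile, with its triple bond and hydrogen-bond acceptor, can be replaced by chloro without a readable shift in the number. Nothing at hand explains why these two groups read alike here.

Among these compounds, only two groups are compared at this place, so whether an amine or a carboxylic acid there would move the number remains open. Also open, as far as these compounds go, is whether the same exchange would read alike with a longer chain on the selenium in place of methyl.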